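Bromo substitution on two pyrazoline-bearing cores

The source may hold more compounds than are shown below. What is called first, only, known or untested is meant among the compounds shown, and "the series" means these compounds.

Measured compounds:
compound 1, `COc1ccc(C2CC(c3ccccc3)=NN2C2=NC(=O)/C(=C3\C(=O)Nc4ccccc43)S2)cc1`, 2300 nM
compound 2, `COc1ccc(C2CC(c3ccccc3)=NN2C2=NC(=O)/C(=C3\C(=O)Nc4ccc(Br)cc43)S2)cc1`, 230 nM
compound 3, `COc1ccc(C2=NN(C3=NC(=O)/C(=C4\C(=O)Nc5ccccc54)S3)C(c3ccc(Cl)cc3)C2)cc1`, 100000 nM

All three were run in a functional assay on cells (Cancer cell lines, Homo sapiens) for cytotoxicity, read by sulforhodamine B assay, with a stated time of 48 h; on this read-out higher numbers stand for weaker inhibition of growth and lower numbers for stronger inhibition of growth. Compound 1 and compound 2 share a core and differ only by bromo in place of hydrogen on an aromatic carbon; this change gave a 10-fold lower number from compound 1 to compound 2 (1.00 log units; beyond the scatter). Compound 3 carries a different core; the difference between the two cores is not broken down here. Compound 3 gives the highest number of the three in this assay, and its value stands well apart from that of compound 1 and further still from that of compound 2.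

Compound 4, `COc1ccc(C2=NN(C3=NC(=O)/C(=C4\C(=O)Nc5ccc(Br)cc54)S3)C(c3ccc(Cl)cc3)C2)cc1`, has not been measured. It is related to compound 3 by bromo in place of hydrogen on an aromatic carbon, the same kind of change as that from compound 1 to compound 2, at a place described in the same words. Among the compounds shown this change occurs twice, once measured and once not.

The expectation for compound 4 rests on a single precedent: the step from compound 1 to compound 2, which was a 10-fold lower number from compound 1 to compound 2 (1.00 log units; beyond the scatter). Carrying that step across to the core of compound 3 is uncertain, since the cores differ and the measured change has been seen only once. Compound 4 is therefore expected to give a step of about a 6.7-fold lower number from compound 3 to compound 4 (0.82 log units; beyond the scatter), with wide bounds. In this assay compound 4 is estimated at 15000 nM, expected to lie between 3000 nM and 100000 nM. Given the value of compound 3 at 100000 nM, the number for compound 4 is expected to remain high in this assay.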

Compound 4, concentration for 50% growth inhibition: 190 nM
Compound 4: the middle estimate sits 79-fold (1.90 log units) above what was measured; the whole stated range lies above it.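

In this assay, bromo in place of hydrogen on an aromatic carbon lowers the number on both cores, and on the second core the step is large, with a 530-fold lower number from compound 3 to compound 4 (2.72 log units; beyond the scatter). The direction of the change carried from one core to the other, but its size did not: the same change on two cores in this assay, a 10-fold lower number (1.00 log units; beyond the scatter) from compound 1 to compound 2 and a 530-fold lower number (2.72 log units; beyond the scatter) from compound 3 to compound 4, 53-fold (1.72 log units) apart, beyond the scatter of two such steps. Within the data shown here, with only one pair per core, this shows that the size of the step cannot be taken as constant across these two cores; it does not show which feature of the cores accounts for the gap, and it gives no rule for a third core.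

The compounds shown leave open whether fluoro, nitro or an amine on the same aromatic carbon would give steps like that of bromo, or whether the result is particular to bromo. Also open, going by these compounds, is how large the step would be on a core carrying only some of the differences between the core of compound 1 and the core of compound 3, since those differences are not separated here into single changes.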